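Methyl to ethynyl: working notes on compound 3

The compounds below may be only part of what the source reports. "The series", "measured", "known", "first", "only" and "open" are said of these compounds alone.

Within the data shown here, in a functional assay on MDA-MB-231 cells (Homo sapiens) for antiproliferative activity, read by MTT assay, with a stated time of 72 h (on this read-out higher numbers stand for weaker inhibition and lower numbers for stronger inhibition), compound 2 `Cc1ccc(NC(=O)CCc2cccc3c2B(O)OC3)cc1` gives 1100 nM, the lower of the two numbers measured so far. Compound 1 `O=C(CCc1cccc2c1B(O)OC2)Nc1ccc(Br)cc1` gives 5300 nM.

Compound 3 `C#Cc1ccc(NC(=O)CCc2cccc3c2B(O)OC3)cc1` carries ethynyl in place of methyl on an aromatic carbon, para to a large group: ethynyl in place of methyl on an aromatic carbon. Among the measured compounds shown here, only one measured step bears on this place: a 4.8-fold lower number from compound 1 to compound 2 (0.68 log units; beyond the scatter), with methyl in place of bromo. That step is modest but beyond the scatter, so a change at this carbon can move the number. For the measured compounds named here, still, a single step cannot show a trend, and no compound with ethynyl has been measured.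

No step beyond the scatter is therefore expected in this assay, with a slight lean towards a higher number, since compound 2 already holds the lower value at 1100 nM. The expected change is a 1.4-fold higher number from compound 2 to compound 3 (0.13 log units; within the scatter). For compound 3 the estimated value is 1500 nM, with an expected range of 500 nM to 4500 nM.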

Compound 3, half-maximal inhibitory concentration: 6600 nM
For compound 3 the middle estimate is 4.4-fold (0.64 log units) below the measured one; the measured number lies above the stated range.
By their numbers in this assay, from the lowest: compound 2; then compounds 1 and 3 (each within the scatter of the next).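

Replacing methyl with ethynyl on this aromatic carbon gives, in this assay, a 6.0-fold higher number from compound 2 to compound 3 (0.78 log units; beyond the scatter) and so reverses the direction of the earlier replacement of bromo with methyl, which gave a 4.8-fold lower number from compound 1 to compound 2 (0.68 log units; beyond the scatter). Ethynyl in place of bromo gives a 1.2-fold higher number from compound 1 to compound 3 (0.10 log units; within the scatter) and so does not separate these two groups in this series. Among these compounds, of the three groups at this position, methyl alone stands apart, and compound 2 is the most potent of the three, since its steps to compound 1 and compound 3 both lie beyond the scatter, which the single step from compound 1 to compound 2 could not show.

Nothing on hand explains why methyl stands apart from bromo and ethynyl at this carbon. On these data alone, it remains open whether the lower number belongs to methyl alone or extends to other groups at this carbon, such as ethyl, methoxy or an amine, and whether the same ordering of the three groups would hold with a different chain linking the amide to the shared core.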